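Swapping Isobutyl for Pyrrolidinyl on the Fused Core

A few compounds are considered here, and "the series" means these few. Any claim that something is new, unique, unknown or untested is made for them only; others in the source may bear on it.

Three compounds have been measured in a functional assay on cells for antagonist activity at prostaglandin E2 receptor EP1 subtype (Rattus norvegicus), read by fluorescence and calcium flux, with a stated time of 60 s; on this read-out higher numbers stand for weaker inhibition and lower numbers for stronger inhibition:

Compound 1 `O=C(O)c1cccc(Cc2c(-c3ccco3)nn3cc(Cl)ccc23)n1` gives 1200 nM.
Compound 2 `O=C(O)c1cccc(Cc2c(-c3ccoc3)nn3cc(Cl)ccc23)n1` gives 130 nM.
Compound 3 `CC(C)Cc1nn2cc(Cl)ccc2c1Cc1cccc(C(=O)O)n1` gives 200 nM.

Compound 3 holds the second highest of the three numbers. Its nearest neighbour is compound 2, and a 1.5-fold higher number from compound 2 to compound 3 (0.19 log units; within the scatter), so the two are indistinguishable on this read-out. Compound 1 lies furthest away: a 6.0-fold lower number from compound 1 to compound 3 (0.78 log units; beyond the scatter), and a 9.2-fold lower number from compound 1 to compound 2 (0.97 log units; beyond the scatter), so compound 1 is the weakest of the three.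

Compound 4 `O=C(O)c1cccc(Cc2c(N3CCCC3)nn3cc(Cl)ccc23)n1` differs from compound 3 in one place: pyrrolidin-1-yl in place of isobutyl on an aromatic carbon.

Among the compounds with values here, no measured step touches a pyrrolidin-1-yl group, so nothing bears on this change directly. Within the data shown here, the closest precedent is the exchange between a five-membered aromatic ring and the isobutyl chain, where a 1.5-fold higher number from compound 2 to compound 3 (0.19 log units; within the scatter); the other two steps, both starting from compound 1, were modest and involved furan-2-yl, which compound 4 does not carry. On that basis a step in this assay that stays within the scatter is expected, with no firm direction; the estimated step is a 1.3-fold higher number from compound 3 to compound 4 (0.10 log units; within the scatter). Compound 4 is therefore expected to give about 250 nM, with a plausible range from 80 nM to 800 nM.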

Compound 4, half-maximal inhibitory concentration: 1800 nM
For compound 4 the middle estimate is 7.2-fold (0.86 log units) below the measured one, and the stated range ends below it.
By their numbers in this assay, from the lowest: compounds 2 and 3 (each within the scatter of the next); then compounds 1 and 4 (each within the scatter of the next).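

In this assay, within the data shown here, this position, on the five-membered aromatic ring, proves far less tolerant than the earlier compounds suggested: pyrrolidin-1-yl, with 5 heavy atoms against 4 for isobutyl, gives a 9.0-fold higher number from compound 3 to compound 4 (0.95 log units; beyond the scatter). The same exchange made against the furan-3-yl of compound 2 gives a 14-fold higher number from compound 2 to compound 4 (1.14 log units; beyond the scatter), whereas against the furan-2-yl of compound 1 it gives a 1.5-fold higher number from compound 1 to compound 4 (0.18 log units; within the scatter), so the four compounds fall into two pairs, compounds 2 and 3 with the lower numbers and compounds 1 and 4 with the higher ones. A ring at this position does not by itself set the result, since ring-bearing compound 2 pairs with the open-chain isobutyl of compound 3, while compounds 1 and 4 also carry rings yet pair with each other.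

Nothing available explains why these groups divide in this way. From the compounds shown here alone, it also remains open whether an open-chain amine such as diethylamino, a piperidine ring or a chain longer than isobutyl would join the pair with the lower numbers or the pair with the higher ones.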